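The compounds below may be only part of what the source reports. "The series", "measured", "known", "first", "only" and "open" are said of these compounds alone.

Three compounds share one core: compound 1 `COc1ccc(/C=C/C(=O)c2ccc(N)c(-c3ccc(F)cc3)c2)cc1O`, compound 2 `COc1cc(/C=C/C(=O)c2ccc(N)c(-c3ccc(F)cc3)c2)ccc1O` and compound 3 `COc1ccc(/C=C/C(=O)c2ccc(N)c(-c3ccc(F)cc3)c2)cc1`. In a functional assay on HepG2 cells (Homo sapiens) for cytotoxicity, read by sulforhodamine B assay, with a stated time of 48 h (a higher number here means a weaker inhibitor, a lower number a stronger inhibitor), compound 1 has the entry "not determined" (no result reported), so it offers no number for comparison. Compound 2 gives 4300 nM and compound 3 gives 3750 nM, and these two values lie within the scatter of each other. The unmeasured compound 4 `Nc1ccc(C(=O)/C=C/c2ccc(O)c(F)c2)cc1-c1ccc(F)cc1` differs from compound 3 on a double-bonded chain carbon bound to a double-bonded chain carbon: 3-fluoro-4-hydroxyphenyl in place of 4-methoxyphenyl on a double-bonded chain carbon bound to a double-bonded chain carbon. Within the data shown here, only one measured step bears on this change, a 1.1-fold lower number from compound 2 to compound 3 (0.06 log units; within the scatter), which swaps the 4-hydroxy-3-methoxyphenyl for the 4-methoxyphenyl and stays within the scatter. Among the measured compounds shown here, no measured step involves a 3-fluoro-4-hydroxyphenyl, so the evidence is indirect. In this assay no change beyond the scatter is therefore expected, and no direction is favoured. The expected size is a 1.0-fold higher number from compound 3 to compound 4 (0.01 log units; within the scatter). For compound 4 the estimated value is 3800 nM, with an expected range from 1800 nM to 8000 nM.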

Compound 4, half-maximal inhibitory concentration: 11700 nM
Compound 4: middle estimate off by 3.1-fold (0.49 log units), on the low side; measured number above the stated range.
By their numbers in this assay, from the lowest: compounds 3 and 2 (each within the scatter of the next); then compound 4.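

In this assay, this position on a double-bonded chain carbon bound to a double-bonded chain carbon proves sensitive to the group it carries: the earlier exchange stayed within the scatter, whereas a 3.1-fold higher number from compound 3 to compound 4 (0.49 log units; beyond the scatter) lies beyond it, a modest step. The narrower change of fluoro in place of methoxy on an aromatic carbon gives a modest step of its own, a 2.7-fold higher number from compound 2 to compound 4 (0.43 log units; beyond the scatter), and here the 4-hydroxy group is present on both sides of the comparison. Among these compounds, then, the weaker result goes with the fluoro and not with the hydroxy alone, though nothing given here explains the rise.

As far as these compounds go, it remains open whether a chloro or a methyl on that aromatic carbon would behave like the fluoro or like the methoxy. Also open, from the compounds shown here alone, is how an amine in place of the hydroxy would fare.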